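Cyano to Trifluoromethyl on Two Related Cores

The source may report more compounds than this note shows. Statements on the series, on what has been measured and on what is new or still open speak of the compounds shown alone.

Measured compounds:
Compound 1, `CC1(C)Oc2ccc(C#N)cc2[C@@H](n2ccccc2=O)[C@@H]1O`: 760 nM
Compound 2, `CC1(C)Oc2ccc(C(F)(F)F)cc2[C@@H](n2ccccc2=O)[C@@H]1O`: 540 nM
Compound 3, `CC1(C)C=C(N2CCCCC2=O)c2cc(C#N)ccc2O1`: 1100 nM

The three measured compounds were tested in a functional assay (trachea) for inhibition, with Cavia porcellus as the target; a lower number here means a stronger inhibitor, a higher number a weaker inhibitor. Compound 1 gives 760 nM, and compound 2 gives 540 nM. The two differ only in the change (trifluoromethyl in place of cyano on an aromatic carbon), which made the step of a 1.4-fold lower number from compound 1 to compound 2 (0.15 log units; within the scatter). The difference between the core of compound 1 and the core of compound 3 is not broken down here; compound 3 gives 1100 nM in this assay, and its value against that of compound 1 lies within the scatter, while against that of compound 2 it lies beyond it.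

Compound 4, `CC1(C)C=C(N2CCCCC2=O)c2cc(C(F)(F)F)ccc2O1`, has not yet been measured. It relates to compound 3 by the change (trifluoromethyl in place of cyano on an aromatic carbon), which is the same change that connects compound 1 to compound 2. On that basis compound 4 is expected to show a step of about a 1.4-fold lower number from compound 3 to compound 4 (0.14 log units; within the scatter) in this assay, of the same size as the earlier one, because the only measured case of this change is a 1.4-fold lower number from compound 1 to compound 2 (0.15 log units; within the scatter). The expectation rests on one pair alone and on a core that differs from that of compound 3 in an unspecified way, so the range is kept wide. Compound 4 is estimated at 800 nM, with a likely range from 350 nM to 1800 nM.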

Compound 4, half-maximal inhibitory concentration: 650 nM
Beside the measured number, compound 4's estimate is 1.2-fold (0.09 log units) above it; the measured number falls inside the stated range.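

In this assay the replacement of cyano by trifluoromethyl on the aromatic carbon of the second core gives a 1.7-fold lower number from compound 3 to compound 4 (0.23 log units; within the scatter) and so stays within the scatter, as it did on the first core. What this shows is limited but consistent: in this series the change carries from one core to the other without any step beyond the scatter, and neither core departs from the other in how it responds. It does not show that the change itself shifts the inhibition, since neither step can be separated from the scatter, and two pairs cannot say how the change would behave on a further core, but the two steps do agree with each other: the same change on two cores in this assay, a 1.4-fold lower number (0.15 log units; within the scatter) from compound 1 to compound 2 and a 1.7-fold lower number (0.23 log units; within the scatter) from compound 3 to compound 4, 1.2-fold (0.08 log units) apart, within the scatter of two such steps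

The compounds shown leave open whether other groups on that aromatic carbon, such as a carboxylic acid, an amine or a longer chain, would give a step beyond the scatter on either core. They also leave open how the same replacement of cyano by trifluoromethyl would read on a third core, for example one carrying an amine where compound 1 carries its hydroxyl group.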